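A few compounds are considered here, and "the series" means these few. Any claim that something is new, unique, unknown or untested is made for them only; others in the source may bear on it.

Compound 1 `COc1ccc(COc2cc(N)c(Cl)cc2C(=O)CCCCN2CCCCC2)cc1`, 8.4; compound 2 `COc1ccc(COc2cc(N)c(Cl)cc2C(=O)CCCCN2CCCCC2)cc1OC`, 8.5; compound 3 `COc1cc(COc2cc(N)c(Cl)cc2C(=O)CCCCN2CCC(C)CC2)cc(OC)c1`, 8.3.

All three were measured in a functional assay for antagonist activity at 5-hydroxytryptamine receptor 4 (Rattus norvegicus); a higher number here means a more potent compound, by a factor of ten per unit of this negative logarithm, a lower number a less potent compound. Compound 3 carries the lowest of the three numbers, yet its gap to compound 1 and its gap to compound 2 both lie within the scatter, so no order among them can be claimed. Within the data shown here, the only step between two measured compounds that differ in one place is a number 0.10 log units higher from compound 1 to compound 2 (within the scatter); it concerns an aromatic carbon and does not bear on the change now considered. Compound 4 `COc1cc(COc2cc(N)c(Cl)cc2C(=O)CCCCN2CCC(c3ccccc3)CC2)cc(OC)c1` differs from compound 3 by phenyl in place of methyl on a saturated ring carbon. Among the measured compounds shown here, compound 1 and compound 3 differ at the saturated ring, but no single step joins them, and their two values lie within the scatter of each other. For the measured compounds named here, no measured step speaks to this position, so the expectation rests on the size of the change alone. The step expected is a number 0.50 log units lower from compound 3 to compound 4 (beyond the scatter), a modest loss with wide uncertainty. Compound 4 is therefore estimated at 7.8, with a range from 7 to 8.6.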

Compound 4, negative logarithm of the antagonist equilibrium constant: 7.7
Compound 4: the middle estimate sits 0.10 log units above what was measured; measured number inside the range.
By their numbers in this assay, from the lowest: compound 4; then compounds 3, 1 and 2 (each within the scatter of the next).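

In this assay, the change from 4-methylpiperidin-1-yl to 4-phenylpiperidin-1-yl gives a number 0.60 log units lower from compound 3 to compound 4 (beyond the scatter), the first step at this saturated ring carbon and the first among these compounds to lie beyond the scatter. The position therefore responds to the group it carries, although compound 4 still retains 7.7. Nothing available accounts for this loss.

One step cannot separate the effect of the aromatic ring from that of the added carbons. As far as these compounds go, what a cyclohexyl group, a benzyl group or an amine would give on the same ring carbon remains open.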